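Swapping the aryl on the piperazine: compound 3 to compound 4

A few compounds are considered here, and "the series" means these few. Any claim that something is new, unique, unknown or untested is made for them only; others in the source may bear on it.

Measured so far:
- compound 1 `COc1cccc(CN(NC(=O)NCCCN2CCN(c3ccccc3OC)CC2)c2ccc(F)cc2)c1`: 5.9 nM
- compound 2 `O=C(NCCCN1CCN(c2ccc(Cl)cc2)CC1)NN(Cc1ccccc1)c1ccccc1`: 9.7 nM
- compound 3 `O=C(NCCCN1CCN(c2ccc(Cl)cc2)CC1)NN(Cc1ccc(F)cc1)c1ccccc1`: 17 nM

In an assay on CHO cells for displacement of a labelled ligand from D(4) dopamine receptor (Homo sapiens), read by radioligand binding (a lower number here means a stronger inhibitor, a higher number a weaker inhibitor), compound 3 gives the highest of the three numbers. For the measured compounds named here, its nearest neighbour is compound 2, whose number is lower by a step that stays within the scatter: a 1.8-fold higher number from compound 2 to compound 3 (0.24 log units; within the scatter), the only change being a fluoro in place of hydrogen on an aromatic carbon. Going by the values given here, compound 1 lies further off, with a number lower than that of compound 3 by a gap beyond the scatter, but compound 1 and compound 3 differ in several places at once, so no single step between them can be drawn.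

Compound 4 `O=C(NCCCN1CCN(c2ncccn2)CC1)NN(Cc1ccc(F)cc1)c1ccccc1` differs from compound 3 in one place: pyrimidin-2-yl in place of 4-chlorophenyl on an amine nitrogen in a ring. Among the compounds with values here, none of the measured steps touches this part of the molecule; the only measured step changes the benzyl arm instead, and it was small. The new ring replaces a carbon-only ring by one with two hetero atoms at the end of the chain where compounds 1 and 2 also carry a carbon ring with a small substituent. Within the data shown here, with no direct precedent, a modest weakening is the most cautious expectation, and compound 4 is estimated at 40 nM, in the range 10 nM to 160 nM, corresponding to an expected step of a 2.4-fold higher number from compound 3 to compound 4 (0.37 log units; beyond the scatter).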

Compound 4, inhibition constant: 19 nM
For compound 4 the middle estimate is 2.1-fold (0.32 log units) above the measured one; measured number inside the range.
By their numbers in this assay, from the lowest: compounds 1, 2, 3 and 4 (each within the scatter of the next, the first and the last beyond it).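

In this assay, pyrimidin-2-yl in place of 4-chlorophenyl on an amine nitrogen in a ring gives a 1.1-fold higher number from compound 3 to compound 4 (0.05 log units; within the scatter), so compound 3 and compound 4 cannot be told apart. For the compounds shown here, the one earlier step changed only the benzyl arm, whereas this one shows that a ring of carbon only and a ring with two hetero atoms, carrying two hydrogen-bond acceptors, can read alike at this end of the molecule. No measurement shown here offers a reason for this result.

On these data alone, whether this holds beyond these two rings remains open: a pyridin-2-yl, a cyclohexyl or a plain methyl on the same nitrogen could read quite differently. As far as these compounds go, it is also open whether pyrimidin-2-yl would match 4-chlorophenyl with the unsubstituted benzyl arm of compound 2.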